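The source may report more compounds than this note shows. Statements on the series, on what has been measured and on what is new or still open speak of the compounds shown alone.

Measured compounds:
compound 1 `Oc1ccccc1CNc1ccc(N2CCCCC2)cc1` — "not active" (no number reported) in a functional assay on Jurkat cells (Homo sapiens) for activation, with a stated time of 24 h (a higher number here means that more compound is needed for the effect, a lower number that less compound is needed), no number reported
compound 2 `Cc1ccc(-c2ccc(NCc3ccccc3O)cc2)cc1` — 3790 nM

In this assay compound 2 gives 3790 nM, the only number shown in the series; compound 1 stands beside it without one. Compound 3 `CC(=O)c1ccc(-c2ccc(NCc3ccccc3O)cc2)cc1` differs from compound 2 by acetyl in place of methyl on an aromatic carbon. Among the compounds with values here, no step between measured compounds exists to set a scale for this change, so the expectation rests on compound 2 alone: the step is expected to be small, none beyond the scatter, as a 1.1-fold lower number from compound 2 to compound 3 (0.03 log units; within the scatter). Compound 3 is accordingly expected to give 3500 nM in this assay, with a range of 1000 nM to 12000 nM.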

Compound 3, half-maximal effective concentration: "not active" (no number reported)
Nothing numeric was reported for compound 3, so the estimate cannot be set against anything.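

In this assay, within the data shown here, compound 3 has no number, so no step from compound 2 can be read. The compounds shown leave open what size of change acetyl in place of methyl brings. Nothing shown bears on the cause of this result.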